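The source may report more compounds than this note shows. Statements on the series, on what has been measured and on what is new or still open speak of the compounds shown alone.

Compound 1 `CO[C@H]1CC[C@H]2CCN(C)[C@H]2C1` in an assay on HEK293 cells for antagonist activity at Neuronal acetylcholine receptor; alpha3/beta4 (Rattus norvegicus), read by FLIPR, using a membrane potential dye (a higher number here means a weaker inhibitor, a lower number a stronger inhibitor), gives > 300000 nM, which is a limit of the assay, not a number.
Compound 2 `COCCO[C@H]1CC[C@H]2CCN(C)[C@H]2C1` in this assay gives > 300000 nM, again a limit.
Compound 3 `CO[C@H]1CC=C2CCN(C)[C@H]2C1` in this assay gives > 300000 nM, again a limit.

Compound 3 therefore stands where every measured compound stands: at the limit of > 300000 nM in this assay, at which 3 of the 3 values shown sit. Compound 4 `COCCO[C@H]1CC=C2CCN(C)[C@H]2C1` differs from compound 3 by methoxymethyl in place of hydrogen on a saturated chain carbon bound to an oxygen on a saturated carbon. For the measured compounds named here, the one measured step of the same kind, a step that the two limits leave unreadable from compound 1 to compound 2, runs from one limit to another, so its size cannot be read. Going by the values given here, no readable step bears on the change, and the only comparison available gives no sign of an effect beyond the scatter. The expected step from compound 3 to compound 4 in this assay is a number no higher from compound 3 to compound 4 (the limit leaves the size open), with compound 4 estimated at 300000 nM, between 100000 nM and 1000000 nM, most likely reported again only as a limit.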

Compound 4, half-maximal inhibitory concentration: > 300000 nM
Compound 4: no number, only a limit (the forecaster's own chance of this, stated with the estimate: 90%); the middle value lies on the limit itself.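

For the compounds shown here, compound 3 and compound 4 both give only a limit of the assay, not a number, so no step between them can be read. The compounds shown leave open how strongly any of them inhibits in this assay, and which change to the shared core would give a readable number.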